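Swapping one side group: from compound 2 to compound 3

This account rests on a few compounds, and the source may have more. Where it says the series, first, only, none or still open, it means among the compounds named here.

Values measured in an ADME assay on liver for metabolic stability, with Liver microsome (Homo sapiens) as the target, read by LC-MS, using microsomes (on this read-out lower numbers stand for slow clearance and higher numbers for fast clearance), so far:
- Compound 1 `O=C(NCc1cc(Cl)ccc1-n1cnnn1)[C@@H]1C[C@@H]2C[C@@H]2N1C(=O)[C@H](O)Cn1cccn1` gives < 12 mL.min-1.g-1 as a limit of the assay
- Compound 2 `CC(C)(C)OC[C@@H](O)C(=O)N1[C@H](C(=O)NCc2cc(Cl)ccc2-n2cnnn2)C[C@@H]2C[C@@H]21` gives 21 mL.min-1.g-1 as a measured number

Within the data shown here, compound 2 holds the only true number so far, and the other result is only a limit. Compound 3 `O=C(NCc1cc(Cl)ccc1-n1cnnn1)[C@@H]1C[C@@H]2C[C@@H]2N1C(=O)[C@H](O)C1CCCCC1` has not been measured. Its difference from compound 2 is cyclohexyl in place of (tert-butoxy)methyl on a saturated chain carbon bound to a carbonyl carbon and an oxygen on a saturated carbon and amounts to cyclohexyl in place of (tert-butoxy)methyl on a saturated chain carbon bound to a carbonyl carbon and an oxygen on a saturated carbon. Among the measured compounds shown here, the one measured step (an at least 1.7-fold higher number from compound 1 to compound 2 (0.24 log units; that floor lies within the scatter)) also swapped a group on a saturated chain carbon. As far as these compounds go, it starts from a limit, so its true size stays open. Starting from compound 2 (21 mL.min-1.g-1), only a small rise within the scatter is expected (a 1.4-fold higher number from compound 2 to compound 3 (0.15 log units; within the scatter)). The estimate for compound 3 is 30 mL.min-1.g-1 with an expected range from 13 mL.min-1.g-1 to 65 mL.min-1.g-1 in this assay.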

Compound 3, intrinsic clearance in microsomes: 150 mL.min-1.g-1
Beside the measured number, compound 3's estimate is 5.0-fold (0.70 log units) below it, outside the stated range (above it).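

In this assay, among these compounds, the group on this saturated chain carbon proves able to move clearance well beyond the scatter, which the earlier compounds could not show: cyclohexyl in place of (tert-butoxy)methyl gives a 7.1-fold higher number from compound 2 to compound 3 (0.85 log units; beyond the scatter), although both groups have the same number of heavy atoms. Cyclohexyl in place of (1H-pyrazol-1-yl)methyl gives an at least 12-fold higher number from compound 1 to compound 3 (1.09 log units; beyond the scatter). The true size of that second step stays open, and it can be read only as a minimum, as it starts from a limit of the assay: the limit of < 12 mL.min-1.g-1 in this assay, at which 1 of the 3 values shown sits.

The compounds shown do not separate the effect of adding the carbon ring from that of removing the oxygen of (tert-butoxy)methyl. As far as these compounds go, how a tetrahydropyranyl ring, which has an oxygen within a six-membered ring, or an amine-bearing cyclohexyl would read at this place also remains open.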